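Bromine Out, Methyl In on the Thiophene Ring

This account rests on a few compounds, and the source may have more. Where it says the series, first, only, none or still open, it means among the compounds named here.

For the measured compounds named here, compound 3 `C[C@H]1[C@H](NCc2ccc(Br)s2)C[C@H]2C[C@@H]1C2(C)C` gives 43000 nM in an ADME assay on MDCK cells (Canis lupus familiaris) for cytotoxicity, read by microscopy, with a stated time of 48 h (on this read-out higher numbers stand for lower toxicity in this test and lower numbers for higher toxicity in this test), the highest number among the three compounds measured so far. Its nearest neighbour is compound 1 `C[C@H]1[C@H](NCc2cccs2)C[C@H]2C[C@@H]1C2(C)C`, which gives 25000 nM in this assay; the step between them, a 1.7-fold higher number from compound 1 to compound 3 (0.24 log units; within the scatter), is small. Far below both stands compound 2 `C[C@H]1[C@H](NCc2sccc2C2CCCCC2)C[C@H]2C[C@@H]1C2(C)C`, which gives 1560 nM in this assay, reached through a 16-fold lower number from compound 1 to compound 2 (1.20 log units; beyond the scatter).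

Compound 4 `Cc1ccsc1CN[C@@H]1C[C@H]2C[C@@H]([C@H]1C)C2(C)C` differs from compound 3 by 3-methylthiophen-2-yl in place of 5-bromothiophen-2-yl on a saturated chain carbon bound to an amine nitrogen. Going by the values given here, no measured step covers this exact swap. The two steps that bear on it both start from compound 1: adding a bromine to the thiophene gave a 1.7-fold higher number from compound 1 to compound 3 (0.24 log units; within the scatter), whereas adding a cyclohexyl gave a 16-fold lower number from compound 1 to compound 2 (1.20 log units; beyond the scatter). Taking the bromine away should therefore move the number little, and a methyl is a much smaller addition than a cyclohexyl, so in this assay the step of a 1.7-fold lower number from compound 3 to compound 4 (0.24 log units; within the scatter) is expected to stay within the scatter. Compound 4 is accordingly estimated at 25000 nM, between 8000 nM and 60000 nM.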

Compound 4, minimum cytotoxic concentration: 10000 nM
The estimate for compound 4 lay 2.5-fold (0.40 log units) above the measured number; measured number inside the range.
By their numbers in this assay, from the lowest: compound 2; then compound 4; then compounds 1 and 3 (each within the scatter of the next).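

In this assay even a methyl on an aromatic carbon of the thiophene moves the number beyond the scatter (a 2.5-fold lower number from compound 1 to compound 4 (0.40 log units; beyond the scatter)), in the same direction as cyclohexyl but by a smaller step. Methyl in place of cyclohexyl on an aromatic carbon gives back part of that fall (a 6.4-fold higher number from compound 2 to compound 4 (0.81 log units; beyond the scatter)), so this change is graded rather than all-or-nothing across these compounds. The swap of 5-bromothiophen-2-yl for 3-methylthiophen-2-yl also counts (a 4.3-fold lower number from compound 3 to compound 4 (0.63 log units; beyond the scatter)), even though the two groups have the same count of heavy atoms.

From the compounds shown here alone, how an amine or a hydroxyl on the thiophene would read remains open, as does the number for a methyl on a different aromatic carbon. No measured evidence here explains any of these steps.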